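Swapping the branched acyl chain of compound 1 for a ring

The source may report more compounds than this note shows. Statements on the series, on what has been measured and on what is new or still open speak of the compounds shown alone.

For the measured compounds named here, compound 1 `CCCCC(CC)C(=O)Nc1ccc2ccn(Cc3ccc(C(=O)NS(=O)(=O)c4ccccc4C)cc3OC)c2c1` gives 8.9 in a functional assay (trachea) for antagonist activity, with Cavia porcellus as the target (on this read-out lower numbers stand for lower potency and higher numbers for higher potency (the scale is a negative logarithm)), the highest of the three numbers measured so far. Compound 3 `CCCCC(CC)C(=O)Nc1ccc2ccn(Cc3ccc(C(=O)NS(=O)(=O)c4ccc(Cl)cc4)cc3OC)c2c1` gives 7.8, and compound 2 `CCCCC(CC)C(=O)Nc1ccc2ccn(Cc3ccc(C(=O)NS(=O)(=O)c4ccc(OC)cc4)cc3OC)c2c1` gives 7.4. The measured steps are a number 1.10 log units lower from compound 1 to compound 3 (beyond the scatter) and a number 1.50 log units lower from compound 1 to compound 2 (beyond the scatter); between the two weaker compounds, a number 0.40 log units higher from compound 2 to compound 3 (beyond the scatter). All three measured changes sit on the aryl group attached to the sulfonyl sulfur, and both departures from compound 1 cost potency in this assay.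

Compound 4 `COc1cc(C(=O)NS(=O)(=O)c2ccccc2C)ccc1Cn1ccc2ccc(NC(=O)CC3CCCC3)cc21` differs from compound 1 in a different part of the molecule: cyclopentylmethyl in place of 1-ethylpentyl on a carbonyl carbon. Going by the values given here, none of the measured steps touches the acyl group, so they give no direct guide to the size or direction of this step; they show only that the shared core, with the 2-methylphenyl on the sulfonyl sulfur kept, is where the best number has been found. With the acyl group otherwise unexplored, the expectation is a step of a number 0.40 log units lower from compound 1 to compound 4 (beyond the scatter), a modest fall that may well lie within the scatter. Compound 4 is therefore estimated at 8.5 in this assay, with a range from 7.7 to 9.2.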

Compound 4, negative logarithm of the antagonist equilibrium constant: 9.9
Estimate against measurement, compound 4: 1.40 log units below, outside the stated range (above it).
By their numbers in this assay, from the lowest: compound 2; then compound 3; then compound 1; then compound 4.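

Compound 4 shows that the acyl group on the amide-type nitrogen is a place where the number in this assay can still rise: cyclopentylmethyl in place of 1-ethylpentyl gives a number 1.00 log units higher from compound 1 to compound 4 (beyond the scatter). Every earlier step away from compound 1 changed the aryl group on the sulfonyl sulfur and lowered the number, whereas this change, from a chain with no ring to one five-membered non-aromatic ring of carbon only, raises it, so the 1-ethylpentyl group is not required for high potency in this series. No supporting evidence bears on why this change raises the number.

The compounds shown leave open whether the ring itself matters, since cyclohexylmethyl, a cyclopentyl group directly on the carbonyl carbon and an unbranched hexyl chain have no values here to set against cyclopentylmethyl. They also leave open whether cyclopentylmethyl would raise the number in the same way with the 4-chlorophenyl of compound 3 or the 4-methoxyphenyl of compound 2 on the sulfonyl sulfur.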